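Shifting a Methoxy Group: What to Expect for Compound 4

The compounds below may be only part of what the source reports. "The series", "measured", "known", "first", "only" and "open" are said of these compounds alone.

Measured so far:
compound 1 `Cc1nc(-c2ccc(Cl)cc2)sc1C(=O)CSc1nc(-c2ccccc2)c(C#N)c(=O)[nH]1` with 83.1%
compound 2 `COc1ccc(-c2nc(C)c(C(=O)CSc3nc(-c4cccc(OC)c4)c(C#N)c(=O)[nH]3)s2)cc1` with 66.7%
compound 3 `COc1ccc(-c2nc(SCC(=O)c3sc(-c4ccc(Cl)cc4)nc3C)[nH]c(=O)c2C#N)cc1` with 88.3%

In a functional assay on U-87MG ATCC cells for antiproliferative activity against U-87 MG (Homo sapiens), read by MTT assay, with a stated time of 48 h, tested at 10 uM (a higher number here means a weaker effect of the compound at the concentration tested, a lower number a stronger effect), compound 3 gives the highest of the three numbers. Compound 1 is nearest, and the step of a number 5.2 percentage points higher from compound 1 to compound 3 (within the scatter) stays within the scatter, so the two cannot be told apart. Compound 2 is furthest, and its value lies beyond the scatter from that of compound 3.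

Compound 4 `COc1cccc(-c2nc(SCC(=O)c3sc(-c4ccc(Cl)cc4)nc3C)[nH]c(=O)c2C#N)c1` has not been measured. It differs from compound 3 by 3-methoxyphenyl in place of 4-methoxyphenyl on an aromatic carbon. Among the measured compounds shown here, no measured step covers exactly this change. For the measured compounds named here, the only measured step, methoxy in place of hydrogen, was within the scatter and concerns another change. Compound 2 also carries 3-methoxyphenyl at that position, but it differs from compound 3 in a second place as well, so its number can only hint at the direction.

Taking that hint with caution, compound 4 is expected to show a small step of a number 10.3 percentage points lower from compound 3 to compound 4 (beyond the scatter) toward a stronger effect, perhaps not beyond the scatter. The estimated value for compound 4 in this assay is 78%, with a range from 62% to 92%.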

Compound 4, a percentage reported as activity, at one concentration (the size of the read-out at that concentration, not a potency): 89.7%
Compound 4: the middle estimate sits 11.7 percentage points below what was measured, within the range that was stated.
By their numbers in this assay, from the lowest: compound 2; then compounds 1, 3 and 4 (each within the scatter of the next).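

In this assay, moving the methoxy group on the aromatic carbon ortho to a cyano group, from 4-methoxyphenyl to 3-methoxyphenyl, gives a number 1.4 percentage points higher from compound 3 to compound 4 (within the scatter), so this shift makes no readable difference in this series. Methoxy in place of hydrogen on that aryl ring gives a number 6.6 percentage points higher from compound 1 to compound 4 (within the scatter) for the 3-methoxyphenyl compound, which matches a number 5.2 percentage points higher from compound 1 to compound 3 (within the scatter) for the 4-methoxyphenyl compound, so neither placement can be told apart from having no methoxy group there. The step that does leave the scatter lies elsewhere in the molecule: chloro in place of methoxy gives a number 23 percentage points higher from compound 2 to compound 4 (beyond the scatter), which ties the stronger effect of compound 2 to the methoxy at that other place, since 3-methoxyphenyl is common to both compounds.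

The compounds shown leave open whether this position is equally insensitive to a group of a different kind, such as an amine or a carboxylic acid on that aryl ring. Nothing available here explains why one place responds to a change and the other does not.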